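A Small Expected Step from Compound 1 to Compound 4

The source may report more compounds than this note shows. Statements on the series, on what has been measured and on what is new or still open speak of the compounds shown alone.

In a physicochemical assay for lipophilicity (a lower number here means a more polar compound, a higher number a more lipophilic compound), compound 1 (`CCNC(=O)Nc1ccc(-c2nccc([C@]34CCOC[C@H]3C4)n2)cc1`) gives 3.9 and lies within the scatter of the other two measured compounds. Compound 2 (`Oc1cccc(-c2nccc([C@]34CCOC[C@H]3C4)n2)c1`) gives 4 and compound 3 (`CS(=O)(=O)Cc1cc([C@]23CCOC[C@H]2C3)nc(-c2cccc(O)c2)n1`) gives 3.7 in the same measurement. Compound 4 (`CCNC(=O)Nc1ccc(-c2nc(C(C)(C)S(C)(=O)=O)cc([C@]34CCOC[C@H]3C4)n2)cc1`) has 1-methyl-1-(methylsulfonyl)ethyl in place of hydrogen on an aromatic carbon. Within the data shown here, the only measured step that bears on this is a number 0.30 log units lower from compound 2 to compound 3 (within the scatter) for (methylsulfonyl)methyl in place of hydrogen on an aromatic carbon, a related but not identical group. On that evidence, the expected change is small and downward, and no shift beyond the scatter is expected. The estimate is a number 0.20 log units lower from compound 1 to compound 4 (within the scatter) in this measurement. Compound 4 is expected at 3.7 (estimated range 3.3 to 4.1).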

Compound 4, partition coefficient: 4.7
The estimate for compound 4 lay 1.00 log units below the measured number; the whole stated range lies below it.
By their numbers in this assay, from the lowest: compounds 3, 1 and 2 (each within the scatter of the next); then compound 4.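

In this assay, among these compounds, the 1-methyl-1-(methylsulfonyl)ethyl group on this aromatic carbon gives a number 0.80 log units higher from compound 1 to compound 4 (beyond the scatter) and so is the first step here beyond the scatter. This carbon of the core of compound 1 can therefore carry a substituent that clearly moves the number, and the direction is opposite to a number 0.30 log units lower from compound 2 to compound 3 (within the scatter) for the related group on another core. Nothing shown gives a reason for this rise.

Open, on these data alone, is whether (methylsulfonyl)methyl on the core of compound 1 would move the number as far. An amine or a carboxylic acid in this place also remains to be read.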